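Ester swap on the shared core: compound 2 to compound 3

The source may hold more compounds than are shown below. What is called first, only, known or untested is meant among the compounds shown, and "the series" means these compounds.

In an ADME assay on HepG2 cells (Homo sapiens) for cytotoxicity, read by neutral red uptake, with a stated time of 24 h (on this read-out higher numbers stand for weaker inhibition and lower numbers for stronger inhibition), compound 1 `CCCCCCCCCCCCCCCC(=O)Oc1c(C(C)C)cc2c3c1OC(=O)[C@@]31CCCC(C)(C)[C@@H]1CC2` gives > 1000000 nM as its reading, and this is a limit of the assay, not a number.

Within the data shown here, compound 2 `CC(C)c1cc2c3c(c1OC(=O)c1ccccc1)OC(=O)[C@@]31CCCC(C)(C)[C@@H]1CC2` gives 510000 nM in this assay and so holds the only number so far, on the weak-inhibition side of the read-out.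

Compound 3 `CC(C)c1cc2c3c(c1OC(=O)CCCc1c[nH]c4ccccc14)OC(=O)[C@@]31CCCC(C)(C)[C@@H]1CC2` is not yet measured and differs from compound 2 in one place: 3-(1H-indol-3-yl)propyl in place of phenyl on a carbonyl carbon on a carbonyl carbon, with the shared core unchanged.

Among the measured compounds shown here, no measured step speaks to this change. In this assay the expectation is a small move toward stronger inhibition, about the size of the scatter and no more. That expectation rests on compound 2 alone, whose 510000 nM sits high on the scale.

The expected change is a 1.7-fold lower number from compound 2 to compound 3 (0.23 log units; within the scatter) and remains an estimate built on one number.

For compound 3 the estimated value is 300000 nM with an expected range of 80000 nM to 1000000 nM in this read-out.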

Compound 3, half-maximal inhibitory concentration: 120000 nM
For compound 3 the middle estimate is 2.5-fold (0.40 log units) above the measured one, and the stated range covers the measured number.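

In this assay, the place on a carbonyl carbon whose other neighbours are oxygen next to a carbonyl group now has a measured step: 3-(1H-indol-3-yl)propyl in place of phenyl gives a 4.3-fold lower number from compound 2 to compound 3 (0.63 log units; beyond the scatter), so the choice of ester group on the shared core moves this reading by more than the scatter. The comparison with the long-chain ester points the same way, with 1H-indol-3-yl in place of dodecyl on a saturated chain carbon, three bonds along the chain from a carbonyl carbon, giving an at least 8.3-fold lower number from compound 1 to compound 3 (0.92 log units; beyond the scatter). Compound 1 stands at a limit of the assay, so that second step is a bound and not a full size: the limit of > 1000000 nM in this assay, at which 1 of the 3 values shown sits.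

Phenyl and 3-(1H-indol-3-yl)propyl differ at once in chain, ring type and hydrogen-bond donor, and the compounds shown do not separate these. A 3-phenylpropyl group on the same carbonyl carbon would isolate the chain from the indole, and an amine or a carboxylic acid at the chain end would test whether the step survives a charged group there.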